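A few compounds are considered here, and "the series" means these few. Any claim that something is new, unique, unknown or untested is made for them only; others in the source may bear on it.

Working notes on the series, read in a functional assay on MDA-MB-436 cells (Homo sapiens) for antiproliferative activity, read by MTT assay, with a stated time of 24 h; on this read-out higher numbers stand for weaker inhibition and lower numbers for stronger inhibition. Compound 1 (`CC(C)(C)c1ccc(S(=O)(=O)NC(CC(=O)O)c2ccccc2)cc1`) gives no number here. Compound 1 reads > 100000 nM, and this is a limit of the assay, so the limit of > 100000 nM in this assay, at which 1 of the 2 values shown sits, is where the starting point stands. Compound 2 (`O=C(O)CC(NS(=O)(=O)c1cc(F)cc(F)c1)c1ccccc1`) does give a number, 69400 nM, and it is the only one available so far. Compound 3 (`N#Cc1ccc(S(=O)(=O)NC(CC(=O)O)c2ccccc2)cc1`) has cyano in place of tert-butyl on an aromatic carbon, para to a large group: cyano in place of tert-butyl on an aromatic carbon. Among the compounds with values here, no measured step covers this change. A small shift toward stronger inhibition in this assay is expected, an at least 1.3-fold lower number from compound 1 to compound 3 (0.12 log units; that floor lies within the scatter), and it may not exceed the usual scatter. The reference for that expectation is compound 2 at 69400 nM. A result reported only as a limit remains quite possible. For compound 3 the estimated value is 75000 nM, with an expected range of 30000 nM to 100000 nM.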

Compound 3, half-maximal inhibitory concentration: 59300 nM
Compound 3: the middle estimate sits 1.3-fold (0.10 log units) above what was measured; measured number inside the range.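

At the aromatic carbon para to a large group, cyano in place of tert-butyl gives an at least 1.6-fold lower number from compound 1 to compound 3 (0.22 log units; that floor lies within the scatter) in this assay. Compound 1 carries a limit of the assay, > 100000 nM, and not a number, whereas with cyano at this position compound 3 gives a measured value, the first one at this position in the series. The step can be stated only as a floor, and its true size stays unknown, because one end of it is a limit: the limit of > 100000 nM in this assay, at which 1 of the 3 values shown sits.

The compounds shown leave open whether an amine or a methoxy group at this position would move the number beyond the scatter. They also leave open whether a longer chain here would read differently from cyano in this assay.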